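Ester-to-ketone switch on the dienoate series

The compounds below may be only part of what the source reports. "The series", "measured", "known", "first", "only" and "open" are said of these compounds alone.

Compound 1 `COC(C)(C)CCCC(C)C/C=C/C(C)=C/C(=O)OC1CCC1` is the lower of the two values recorded so far: in a physicochemical assay for lipophilicity (on this read-out higher numbers stand for higher lipophilicity and lower numbers for lower lipophilicity), compound 1 gives 6.44, while compound 2 `CCCC(=O)/C=C(C)/C=C/CC(C)CCCC(C)C` gives 6.81 in this assay, a higher number and beyond the usual scatter. Compound 3 `CCC(C)C(=O)/C=C(C)/C=C/CC(C)CCCC(C)(C)OC` has not yet been measured. Its difference from compound 1 is sec-butyl in place of cyclobutyloxy on a carbonyl carbon, that is, cyclobutyloxycarbonyl to (sec-butyl)carbonyl when the cut is taken one bond further out. The change removes the one hydrogen-bond acceptor of the leaving group and one heavy atom. Within the data shown here, no measured pair shows this exact difference, so the step is judged from the two values in hand. A modest rise is expected, a number 0.26 log units higher from compound 1 to compound 3 (within the scatter), given that compound 2 gives 6.81 in this assay. The estimate for compound 3 in this assay is 6.7, within 6.3 to 7.1.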

Compound 3, partition coefficient: 6.02
Beside the measured number, compound 3's estimate is 0.68 log units above it, and the stated range ends above it.
By their numbers in this assay, from the lowest: compound 3; then compound 1; then compound 2.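

Replacing cyclobutyloxy with sec-butyl on a carbonyl carbon gives a number 0.42 log units lower from compound 1 to compound 3 (beyond the scatter) in this assay. This position therefore registers a change of group on the carbonyl carbon, and here the number falls even though the entering group has no hydrogen-bond acceptor, no ring and one heavy atom fewer. Among these compounds, nothing measured bears on why the number falls, and this single pair is the only reading of the change at this position.

Going by these compounds, the step changes the oxygen and the four-membered ring together, so which of them goes with the lower number remains open. A sec-butoxy group or a cyclobutyl group on the same carbonyl carbon would separate the two, while a longer chain there would show whether the number follows chain length.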